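This account rests on a few compounds, and the source may have more. Where it says the series, first, only, none or still open, it means among the compounds named here.

Compound 1 `Cc1ccc(-n2ccnc2SCC(=O)Nc2ccc(C)cc2Br)cc1`, compound 2 `Cc1ccc(-n2ccnc2SCC(=O)Nc2ccccc2C)cc1` and compound 3 `COc1ccc(-n2ccnc2SCC(=O)Nc2ccccc2Cl)cc1` have been measured. In an ADME assay on MT4 cells (Homo sapiens) for cytotoxicity, read by MTT assay (a higher number here means that more compound is tolerated, a lower number that less compound is tolerated), compound 1 gives 80800 nM. Compound 2 gives 147000 nM. For compound 3 only a limit of the assay is known, namely > 334000 nM. Compound 3 therefore stands at the upper edge of the numbers shown: the limit of > 334000 nM in this assay, at which 1 of the 3 values shown sits.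

Compound 4 `Cc1ccc(-n2ccnc2SCC(=O)Nc2ccccc2Cl)cc1` is not yet measured. It differs from compound 3 by methyl in place of methoxy on an aromatic carbon. For the measured compounds named here, the one measured step, a 1.8-fold higher number from compound 1 to compound 2 (0.26 log units; within the scatter), changes the ring on the amide-type nitrogen rather than the ring altered here, so no measured step bears directly on this change. Only a small step, if any, is expected: an at least 1.6-fold lower number from compound 3 to compound 4 (0.22 log units; that floor lies within the scatter). Compound 4 is estimated at 200000 nM, with a range from 70000 nM to 400000 nM.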

Compound 4, half-maximal cytotoxic concentration: 33700 nM
Compound 4: middle estimate off by 5.9-fold (0.77 log units), on the high side; measured number outside the range, below it.
By their numbers in this assay, from the lowest: compound 4; then compounds 1 and 2 (each within the scatter of the next). At a limit, above all of these: compound 3.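

In this assay, this position proves sensitive, since methyl in place of methoxy gives an at least 9.9-fold lower number from compound 3 to compound 4 (0.99 log units; beyond the scatter). Changes on the amide side of compound 4 also count: chloro in place of methyl gives a 4.4-fold lower number from compound 2 to compound 4 (0.64 log units; beyond the scatter), and 2-chlorophenyl in place of 2-bromo-4-methylphenyl gives a 2.4-fold lower number from compound 1 to compound 4 (0.38 log units; beyond the scatter). Compound 3 is known only by a limit of the assay, so the methoxy step has a floor rather than a full size: the limit of > 334000 nM in this assay, at which 1 of the 4 values shown sits.

Going by these compounds, it remains open whether a hydroxyl, an amine or a longer ether chain at this place would behave like methoxy or like methyl. On these data alone, it is also open whether methoxy would give a similar step with the 2-bromo-4-methylphenyl group on the amide nitrogen.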